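The source may report more compounds than this note shows. Statements on the series, on what has been measured and on what is new or still open speak of the compounds shown alone.

Three compounds share one core and differ only in the placement of a single fluoro. Compound 1 `O=C(CCCCCc1ccccc1)c1nc2c(F)cccc2o1` gives 117 nM in an assay on HEK-293T cells for inhibition of diacylglycerol lipase-alpha (Homo sapiens), read by colorimetric assay; on this read-out higher numbers stand for weaker inhibition and lower numbers for stronger inhibition. Compound 2 `O=C(CCCCCc1ccccc1)c1nc2cc(F)ccc2o1` gives 1410 nM in this assay, and compound 3 `O=C(CCCCCc1ccccc1)c1nc2ccc(F)cc2o1` gives 708 nM in this assay. Compound 3 thus holds the second highest of the three numbers: its value lies within the scatter of that of compound 2, while compound 1 stands beyond the scatter with a lower number. Compound 4 `O=C(CCCCCc1ccccc1)c1nc2ccc(Br)cc2o1` has not yet been measured. It differs from compound 3 by bromo in place of fluoro on an aromatic carbon. For the measured compounds named here, no measured pair shows this swap. In this assay the step is expected to be small, a 1.8-fold lower number from compound 3 to compound 4 (0.25 log units; within the scatter), leaning toward a lower number but quite possibly not beyond the scatter. Compound 4 is therefore expected to give about 400 nM in this assay, with a likely range from 120 nM to 1500 nM.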

Compound 4, half-maximal inhibitory concentration: 5890 nM
Compound 4: the middle estimate sits 15-fold (1.17 log units) below what was measured; the whole stated range lies below it.
By their numbers in this assay, from the lowest: compound 1; then compounds 3 and 2 (each within the scatter of the next); then compound 4.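

In this assay there is an 8.3-fold higher number from compound 3 to compound 4 (0.92 log units; beyond the scatter) with bromo in place of fluoro on an aromatic carbon, so the two halogens are not interchangeable at this position. The earlier compounds shown here showed only that moving the fluoro shifts the number; this step shows that the group held at one fixed place matters too. No measurement shown bears on the cause of this step. From the compounds shown here alone, whether chloro or methyl here would fall nearer compound 3 or compound 4 stays open, as does whether bromo at the fluoro place of compound 1 would bring a similar step.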